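The source may report more compounds than this note shows. Statements on the series, on what has been measured and on what is new or still open speak of the compounds shown alone.

Among the compounds with values here, compound 1 `COc1cc(/C=N/NC(=O)OCc2ccccc2)ccc1O` was tested in a physicochemical assay on cells (Homo sapiens), with a stated time of 18 h, tested at 1 uM (a higher number here means a weaker effect of the compound at the concentration tested, a lower number a stronger effect), where compound 1 gives 75%, the highest of the two numbers so far. Its companion compound 2 `O=C(N/N=C/c1ccc(O)c(O)c1)OCc1ccccc1` differs in one place, hydrogen in place of methyl on an oxygen on an aromatic ring, and in this assay compound 2 gives 27%; the step of a number 48 percentage points lower from compound 1 to compound 2 (beyond the scatter) is large and beyond the scatter. Compound 3 `COc1cc(/C=N/NC(=O)OCc2ccccc2)c(O)cc1O` has not yet been measured. Compared with compound 1 the change is hydroxy in place of hydrogen on an aromatic carbon, on an aromatic carbon of a six-membered aromatic ring of carbon only, ortho to a large group, meta to a hydroxy group and para to a methoxy group. Within the data shown here, no measured step shows exactly this change; the only step available concerns a different group and can guide the expectation only loosely. Because a number 48 percentage points lower from compound 1 to compound 2 (beyond the scatter) accompanied the appearance of a free hydroxy, a downward step of moderate size is expected here too, with wide uncertainty. For compound 3 the expected step is a number 20 percentage points lower from compound 1 to compound 3 (beyond the scatter). The estimate for compound 3 is therefore 55%, within a range of 30% to 80%.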

Compound 3, a percentage reported as activity, at one concentration (the size of the read-out at that concentration, not a potency): 74%
The estimate for compound 3 lay 19 percentage points below the measured number; low and high end bracket the measured number.
By their numbers in this assay, from the lowest: compound 2; then compounds 3 and 1 (each within the scatter of the next).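

In this assay, a hydroxy in place of hydrogen on the aromatic carbon ortho to a large group, meta to a hydroxy group and para to a methoxy group gives a number 1 percentage points lower from compound 1 to compound 3 (within the scatter), so at this position the added hydroxy leaves compounds 1 and 3 within the scatter of each other. The earlier pair showed only a number 48 percentage points lower from compound 1 to compound 2 (beyond the scatter), where a free hydroxy appeared by hydrogen taking the place of methyl on an oxygen; the new pair shows that a hydroxy added at this ring position does not bring a step beyond the scatter, so the earlier step cannot be read as holding for every new hydroxy on this ring. Nothing at hand accounts for the difference between these two changes.

What the compounds shown leave open is whether an amine or a carboxylic acid on this same aromatic carbon would also stay within the scatter of compound 1. Going by these compounds, it also remains open whether this added hydroxy would give the same result with hydrogen in place of methyl on the neighbouring oxygen, as in compound 2.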